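The compounds below may be only part of what the source reports. "The series", "measured", "known", "first", "only" and "open" are said of these compounds alone.

Measured compounds:
- compound 1 `CCC1C(=O)N(C)c2cnc(-n3ccc4cc(C(N)=O)ccc43)nc2N1c1ccn(C)n1`, which in a functional assay on NCI-H1975 cells (Homo sapiens) for antiproliferative activity, read by CCK-8 assay, with a stated time of 72 h (on this read-out lower numbers stand for stronger inhibition of growth and higher numbers for weaker inhibition of growth), gives "not active" (no number reported), with no number given
- compound 2 `CCC1C(=O)N(C)c2cnc(-n3ccc4cc(C(=O)NCC(C)C)ccc43)nc2N1c1ccn(C)n1`, which in this assay gives 10200 nM
- compound 3 `CCC1C(=O)N(C)c2cnc(-n3ccc4cc(C(=O)NC(C)C)ccc43)nc2N1c1ccn(C)n1`, which in this assay gives 12200 nM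

Compound 3 holds the highest of the two numbers, though its nearest neighbour compound 2 sits within the scatter: the step of a 1.2-fold higher number from compound 2 to compound 3 (0.08 log units; within the scatter) is too small to call a change. Compound 4 `CCCCNC(=O)c1ccc2c(ccn2-c2ncc3c(n2)N(c2ccn(C)n2)C(CC)C(=O)N3C)c1` is not yet measured. It differs from compound 3 by butyl in place of isopropyl on an amide-type nitrogen. Among the compounds with values here, the only step that bears on it is the one from compound 2 to compound 3, which was within the scatter, so no step beyond the scatter is expected in this assay. Compound 4 is therefore estimated at 11000 nM, between 5000 nM and 25000 nM, an expected step of a 1.1-fold lower number from compound 3 to compound 4 (0.04 log units; within the scatter).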

Compound 4, concentration for 50% growth inhibition: 12000 nM
Compound 4: middle estimate off by 1.1-fold (0.04 log units), on the low side, within the range that was stated.
By their numbers in this assay, from the lowest: compounds 2, 4 and 3 (each within the scatter of the next).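

In this assay, butyl in place of isopropyl on the amide-type nitrogen gives a 1.0-fold lower number from compound 3 to compound 4 (0.01 log units; within the scatter), and the comparison with the isobutyl group gives a 1.2-fold higher number from compound 2 to compound 4 (0.07 log units; within the scatter). The unbranched butyl chain therefore cannot be told apart from the branched isopropyl and isobutyl groups at this position. Nothing available offers an explanation for this result.

From the compounds shown here alone, whether a longer chain such as octyl would give a different number remains open. So does the effect of a butyl chain ending in an amine or a carboxylic acid.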